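One More Carbon on the Amide-Bearing Chain

The source may report more compounds than this note shows. Statements on the series, on what has been measured and on what is new or still open speak of the compounds shown alone.

Of the compounds shown here, three sharing one core have been measured in a functional assay on MDA-MB-231 cells (Homo sapiens) for antiproliferative activity, read by CCK-8 assay, with a stated time of 72 h; on this read-out higher numbers stand for weaker inhibition and lower numbers for stronger inhibition. Compound 1 `O=C(Nc1cccc(-c2oc3cc(-c4ccc(F)cc4)ccc3c(=O)c2O)c1)c1ccc(F)cc1F` gives 11200 nM. Compound 2 `Cc1cccc(C(=O)Nc2cccc(-c3oc4cc(-c5ccc(F)cc5)ccc4c(=O)c3O)c2)c1` gives 2840 nM, and compound 3 `CCc1ccc(C(=O)Nc2cccc(-c3oc4cc(-c5ccc(F)cc5)ccc4c(=O)c3O)c2)cc1` gives 9070 nM. Among these three numbers, compound 3 holds the second highest. The nearest number belongs to compound 1. That step, a 1.2-fold lower number from compound 1 to compound 3 (0.09 log units; within the scatter), lies within the scatter. The other step touching this compound, a 3.2-fold higher number from compound 2 to compound 3 (0.50 log units; beyond the scatter), is beyond the scatter, as is a 3.9-fold lower number from compound 1 to compound 2 (0.60 log units; beyond the scatter).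

Compound 4 `CCCc1ccc(C(=O)Nc2cccc(-c3oc4cc(-c5ccc(F)cc5)ccc4c(=O)c3O)c2)cc1` differs from compound 3 by a single change: methyl in place of hydrogen on a saturated chain carbon, two bonds along the chain from an aromatic carbon. Within the data shown here, none of the measured steps adds a carbon to a chain; each of them swaps one ring for another on the carbonyl carbon. They show that changes at this part of the molecule can shift the number modestly, as in a 3.2-fold higher number from compound 2 to compound 3 (0.50 log units; beyond the scatter), or hardly at all, as in a 1.2-fold lower number from compound 1 to compound 3 (0.09 log units; within the scatter). Among the measured compounds shown here, with no step of the same kind to lean on, the expectation is a change no larger than the scatter, in no particular direction, and so the expected step is a 1.0-fold lower number from compound 3 to compound 4 (0.00 log units; within the scatter). Compound 4 is therefore estimated at 9000 nM, with a range from 3000 nM to 27000 nM.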

Compound 4, half-maximal inhibitory concentration: 32200 nM
The estimate for compound 4 lay 3.6-fold (0.55 log units) below the measured number, outside the stated range (above it).
By their numbers in this assay, from the lowest: compound 2; then compounds 3 and 1 (each within the scatter of the next); then compound 4.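

In this assay, among these compounds, going from 4-ethylphenyl to 4-propylphenyl is the first chain change seen, and it is not neutral: a 3.6-fold higher number from compound 3 to compound 4 (0.55 log units; beyond the scatter). Among the compounds shown here, one added carbon at this end of the molecule therefore moves the number as far as the earlier ring swaps did, and it moves it towards weaker inhibition, leaving compound 4 the weakest of the four, with a 2.9-fold higher number from compound 1 to compound 4 (0.46 log units; beyond the scatter) and with an 11-fold higher number from compound 2 to compound 4 (1.05 log units; beyond the scatter), the only large step so far. Nothing measured here accounts for this loss of inhibition, so the result can be described but not explained.

Going by these compounds, a single step cannot establish a trend, so it remains open whether a 4-butylphenyl group on the carbonyl carbon would raise the number further and whether a 4-methylphenyl group would lower it. Also open, on these data alone, is whether a chain of similar length carrying an amine or a carboxylic acid would behave like the propyl chain, or whether the loss belongs to the plain carbon chain alone.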